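From 2-chlorophenyl to 3-chlorophenyl: an expected small step

The compounds below may be only part of what the source reports. "The series", "measured", "known", "first", "only" and "open" are said of these compounds alone.

Measured in a functional assay on MCF7 cells (Homo sapiens) for antiproliferative activity, read by MTT assay, with a stated time of 72 h; on this read-out higher numbers stand for weaker inhibition and lower numbers for stronger inhibition:
- compound 1 `O=C(Nc1ccc(Nc2nccc(NC3CCCCC3)n2)cc1)Nc1ccc(Cl)c(C(F)(F)F)c1`: 10800 nM
- compound 2 `O=C(Nc1ccc(Nc2nccc(NC3CC3)n2)cc1)Nc1ccc(Cl)c(C(F)(F)F)c1`: 38300 nM
- compound 3 `O=C(Nc1ccc(Nc2nccc(Nc3ccccc3Cl)n2)cc1)Nc1ccc(Cl)c(C(F)(F)F)c1`: 27900 nM

Among these three numbers, compound 3 at 27900 nM stands level with one neighbour and apart from the other. The record shows a 1.4-fold lower number from compound 2 to compound 3 (0.14 log units; within the scatter), and also a 2.6-fold higher number from compound 1 to compound 3 (0.41 log units; beyond the scatter).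

Compound 4 `O=C(Nc1ccc(Nc2nccc(Nc3cccc(Cl)c3)n2)cc1)Nc1ccc(Cl)c(C(F)(F)F)c1` carries the next change, 3-chlorophenyl in place of 2-chlorophenyl on a nitrogen on an aromatic ring. Among the compounds with values here, no measured pair tests this exact swap. The nearest evidence comes from whole-group exchanges at the same place, and these were small even though the groups differ far more. The record gives a 3.5-fold higher number from compound 1 to compound 2 (0.55 log units; beyond the scatter), a modest step, while the exchange linking the two weaker compounds stayed within the scatter. A swap between two groups of identical composition is therefore expected to produce no step beyond the scatter, and no direction can be favoured with confidence. The expected step is a 1.3-fold lower number from compound 3 to compound 4 (0.10 log units; within the scatter). Compound 4 is estimated at 22000 nM, with an expected range of 9000 nM to 50000 nM.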

Compound 4, half-maximal inhibitory concentration: 10400 nM
Compound 4: middle estimate off by 2.1-fold (0.33 log units), on the high side; measured number inside the range.
By their numbers in this assay, from the lowest: compounds 4 and 1 (each within the scatter of the next); then compounds 3 and 2 (each within the scatter of the next).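

At this place, on a nitrogen on an aromatic ring, two groups made of the same atoms do not behave alike in this assay: 3-chlorophenyl in place of 2-chlorophenyl gives a 2.7-fold lower number from compound 3 to compound 4 (0.43 log units; beyond the scatter), so where the chlorine sits on the phenyl ring counts here. An aromatic group can also stand level with the cyclohexyl group, as a 1.0-fold lower number from compound 1 to compound 4 (0.02 log units; within the scatter) shows, while the same 3-chlorophenyl group in place of cyclopropyl gives a 3.7-fold lower number from compound 2 to compound 4 (0.57 log units; beyond the scatter) and, unlike 2-chlorophenyl, separates from cyclopropyl beyond the scatter. Nothing available gives a reason for this difference between the two chlorophenyl groups.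

The compounds shown leave open whether this step belongs to chlorine itself or would recur with 3-bromophenyl or 3-methoxyphenyl at the same place. They also leave open whether an unsubstituted phenyl would fall with compound 3 or with compound 4.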